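Two Compounds Share One Change; a Third Awaits Its Number

A few compounds are considered here, and "the series" means these few. Any claim that something is new, unique, unknown or untested is made for them only; others in the source may bear on it.

In a functional assay on HepG2 cells (Homo sapiens) for antiproliferative activity (a lower number here means a stronger inhibitor, a higher number a weaker inhibitor), the three measured compounds stand as follows:

Compound 1, `COc1cc(/C=C/C(=O)c2ccc(OCCn3cc(CN4C(=O)/C=C/C(C)(C)C/C=C(\C)CC/C=C/4C)nn3)cc2O)cc(OC)c1OC`, gives 1.44 ug/mL.
Compound 2, `C/C1=C\CC(C)(C)/C=C/C(=O)N(Cc2cn(CCOc3ccc(C(=O)/C=C/c4ccc(C)cc4)c(O)c3)nn2)/C(C)=C/CC1`, gives 0.87 ug/mL.
Compound 3, `COc1cc(/C=C/C(=O)c2ccc(OCCCN3C(=O)/C=C/C(C)(C)C/C=C(\C)CC/C=C/3C)cc2)cc(OC)c1OC`, gives 0.99 ug/mL.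

Compound 1 and compound 2 differ in a single place: 4-methylphenyl in place of 3,4,5-trimethoxyphenyl on a double-bonded chain carbon bound to a double-bonded chain carbon. That change made a step of a 1.7-fold lower number from compound 1 to compound 2 (0.22 log units; within the scatter), a step that stays within the scatter of repeated measurements, so the two numbers cannot be ranked with confidence. Compound 3 is built on a different core from compound 1; the difference between the two cores is not broken down here. Its value sits close to those of both compound 1 and compound 2, and every gap among the three lies within the scatter.

Compound 4, `C/C1=C\CC(C)(C)/C=C/C(=O)N(CCCOc2ccc(C(=O)/C=C/c3ccc(C)cc3)cc2)/C(C)=C/CC1`, has not yet been measured. It differs from compound 3 by 4-methylphenyl in place of 3,4,5-trimethoxyphenyl on a double-bonded chain carbon bound to a double-bonded chain carbon. This is the same change that leads from compound 1 to compound 2, made on the core of compound 3. Among the measured compounds shown here, since the one earlier example of this change gave a 1.7-fold lower number from compound 1 to compound 2 (0.22 log units; within the scatter), a step of about the same size, a 1.5-fold lower number from compound 3 to compound 4 (0.18 log units; within the scatter), is expected here. On that basis compound 4 is estimated at 0.65 ug/mL in this assay, with a likely range from 0.3 ug/mL to 1.4 ug/mL, resting on a single precedent and therefore held loosely.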

Compound 4, half-maximal inhibitory concentration: 1.53 ug/mL
Compound 4: the middle estimate sits 2.4-fold (0.37 log units) below what was measured, outside the stated range (above it).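

In this assay, putting 4-methylphenyl in place of 3,4,5-trimethoxyphenyl on the core of compound 3 gave a 1.5-fold higher number from compound 3 to compound 4 (0.19 log units; within the scatter), so this pair cannot be ranked with confidence, just as the earlier pair could not. On paper the two steps run in opposite directions, but that apparent reversal is no larger than the noise expected when two such steps are compared: the same change on two cores in this assay, a 1.7-fold lower number (0.22 log units; within the scatter) from compound 1 to compound 2 and a 1.5-fold higher number (0.19 log units; within the scatter) from compound 3 to compound 4, 2.6-fold (0.41 log units) apart, within the scatter of two such steps. This shows that the change made no clear difference to the number on either core and offers no firm sign that the core alters its effect, but it does not prove that the change carries over unaltered, since two small, noisy steps could hide a modest real dependence on the core.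

The compounds shown offer only two groups at this place, both built on a six-membered aromatic ring of carbon only, so it remains open whether a group of another kind, such as a carboxylic acid or an amine, would produce a step beyond the scatter. On these data alone, it also remains open which part of the difference between the two cores, if any, matters in this assay, since that difference is not broken down into single changes.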